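Replacing the Allyl Ether with a Dimethylaminopropyl Ether

The source may hold more compounds than are shown below. What is called first, only, known or untested is meant among the compounds shown, and "the series" means these compounds.

Compound 1, `COc1ccc(/C=C/C(=O)c2ccc(OC)c3c2OC(C)(C)C=C3)cc1O`: 800 nM
Compound 2, `C=CCOc1cc(/C=C/C(=O)c2ccc(OC)c3c2OC(C)(C)C=C3)ccc1OC`: > 10000 nM

In a functional assay on A-375 cells (Homo sapiens) for cytotoxicity, read by MTT assay (a higher number here means a weaker inhibitor, a lower number a stronger inhibitor), compound 1 gives 800 nM. For compound 2 this assay reports only a limit, > 10000 nM, so its true value is not known. The measured step between the two, an at least 12-fold higher number from compound 1 to compound 2 (1.09 log units; beyond the scatter), is anchored by the limit of > 10000 nM in this assay, at which 1 of the 2 values shown sits, which is where compound 2 sits.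

Compound 3, `COc1ccc(/C=C/C(=O)c2ccc(OC)c3c2OC(C)(C)C=C3)cc1OCCCN(C)C`, has not yet been measured. It differs from compound 2 by 2-(dimethylamino)ethyl in place of vinyl on a saturated chain carbon bound to an oxygen on an aromatic ring. Going by the values given here, no measured step covers this change: the only measured step concerns hydrogen against allyl on the aromatic oxygen, not the chain that replaces the allyl, so it offers no direction for compound 3. With compound 2 known only as a limit, any expectation is wide. Compound 3 is expected to come out near 5000 nM, with a range from 1000 nM to 20000 nM. The step this estimate means is an at least 2.0-fold lower number from compound 2 to compound 3 (0.30 log units; that floor lies within the scatter), and it is an expectation rather than a measurement.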

Compound 3, half-maximal inhibitory concentration: 4100 nM
Beside the measured number, compound 3's estimate is 1.2-fold (0.09 log units) above it; the measured number falls inside the stated range.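

In this assay, moving from the allyl ether to the 3-(dimethylamino)propyl ether gives an at least 2.4-fold lower number from compound 2 to compound 3 (0.38 log units; beyond the scatter), so an ether on this aromatic oxygen does not in itself carry the value to the limit of the assay. A substituent on this oxygen still costs activity, however, since replacing the hydrogen with 3-(dimethylamino)propyl gives a 5.1-fold higher number from compound 1 to compound 3 (0.71 log units; beyond the scatter). The step from the allyl ether is a floor rather than a measured size, as compound 2 is known only as a limit: the limit of > 10000 nM in this assay, at which 1 of the 3 values shown sits.

The compounds shown leave open whether the change comes from the dimethylamino group or from the chain that carries it, and how a plain propyl chain, a morpholine or a carboxylic acid would read here. They also leave open whether a shorter or longer amine-bearing chain would come closer to compound 1.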